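Two Methyls in Place of a Methoxy on the Benzothiazole

The compounds below may be only part of what the source reports. "The series", "measured", "known", "first", "only" and "open" are said of these compounds alone.

Measured so far:
compound 1 `O=C(Nc1nc2ccc(Cl)cc2s1)c1cc(-c2ccc(F)cc2)n2nc(-c3ccccc3)cc2n1` — 6600 nM
compound 2 `O=C(Nc1nc2ccc(F)cc2s1)c1cc(-c2ccc(F)cc2)n2nc(-c3ccccc3)cc2n1` — 14800 nM
compound 3 `COc1ccc2nc(NC(=O)c3cc(-c4ccc(F)cc4)n4nc(-c5ccccc5)cc4n3)sc2c1` — 24000 nM

All three compounds share one core and differ only in the group on the benzothiazole ring. In a functional assay on A549 cells (Homo sapiens) for cytotoxicity, read by MTT assay, with a stated time of 48 h (a lower number here means a stronger inhibitor, a higher number a weaker inhibitor), compound 3 gives the highest number of the three. Its gap to compound 2 is within the scatter, while the step of a 3.6-fold higher number from compound 1 to compound 3 (0.56 log units; beyond the scatter) is beyond it, so compound 3 is weaker than compound 1 but cannot be ranked against compound 2.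

Compound 4 `Cc1cc2nc(NC(=O)c3cc(-c4ccc(F)cc4)n4nc(-c5ccccc5)cc4n3)sc2cc1C` is not yet measured. The change is 5,6-dimethyl-1,3-benzothiazol-2-yl in place of 6-methoxy-1,3-benzothiazol-2-yl on an amide-type nitrogen. Among the compounds with values here, no measured step swaps a methoxy for methyl groups, so the bearing of the earlier steps is indirect. The steps of a 2.2-fold higher number from compound 1 to compound 2 (0.35 log units; beyond the scatter) and a 1.6-fold higher number from compound 2 to compound 3 (0.21 log units; within the scatter) show that small changes at this ring moved this assay only modestly, with the methoxy compound at the weak end. Removing the methoxy is therefore expected to move the number, if at all, towards the other compounds, and the expected step is a 2.0-fold lower number from compound 3 to compound 4 (0.30 log units; within the scatter). Compound 4 is estimated at 12000 nM, with a range from 5000 nM to 30000 nM.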

Compound 4, half-maximal inhibitory concentration: 12600 nM
Beside the measured number, compound 4's estimate is 1.1-fold (0.02 log units) below it, and the stated range covers the measured number.
By their numbers in this assay, from the lowest: compounds 1, 4, 2 and 3 (each within the scatter of the next, the first and the last beyond it).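

In this assay compound 4, with its 5,6-dimethyl-1,3-benzothiazol-2-yl group, lies within the scatter of all three earlier compounds: the methoxy compound (a 1.9-fold lower number from compound 3 to compound 4 (0.28 log units; within the scatter)), the fluoro compound (a 1.2-fold lower number from compound 2 to compound 4 (0.07 log units; within the scatter)) and the chloro compound (a 1.9-fold higher number from compound 1 to compound 4 (0.28 log units; within the scatter)). Within the data shown here, two methyl groups can therefore stand on this ring, in a group without oxygen, with no readable gain or loss against any earlier compound, and the only gap beyond the scatter remains the one between compound 1 and compound 3. No supporting measurement is available to explain these numbers.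

Still open, going by these compounds, is whether an amine or a carboxylic acid on this ring would move the number clearly away from this band. Also open, on these data alone, is what a single methyl group would do on its own.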